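The source may report more compounds than this note shows. Statements on the series, on what has been measured and on what is new or still open speak of the compounds shown alone.

Of the compounds shown here, three built on one shared core have been tested in a functional assay on RAW264.7 cells (Mus musculus) for inhibition, read by Griess assay, with stated times of 2 h and 24 h; a higher number here means a weaker inhibitor, a lower number a stronger inhibitor. Compound 1 `COc1ccc([C@@H]2CC(=O)c3c(O)cc(OCc4cn(Cc5cccc(C(F)(F)F)c5)nn4)cc3O2)cc1O` gives 19900 nM, compound 2 `COc1ccc([C@@H]2CC(=O)c3c(O)cc(OCc4cn(C5CCCC5)nn4)cc3O2)cc1O` gives 10500 nM, and compound 3 `COc1ccc([C@@H]2C/C(=N\O)c3c(O)cc(OCc4cn(Cc5ccccc5C)nn4)cc3O2)cc1O` gives 18000 nM. Compound 2 thus carries the smallest of the three numbers, though its gaps to compound 3 and to compound 1 both lie within the scatter. Among the measured compounds shown here, the single one-point step among the measured compounds, a 1.9-fold lower number from compound 1 to compound 2 (0.28 log units; within the scatter), is likewise within the scatter. Compound 4 `COc1ccc([C@@H]2CC(=O)c3c(O)cc(OCc4cn(C5CCC5)nn4)cc3O2)cc1O` differs from compound 2 by cyclobutyl in place of cyclopentyl on an aromatic nitrogen. For the measured compounds named here, no measured step exchanges one small carbon ring for another, and the only step at the aromatic nitrogen was modest, so no shift beyond the scatter is expected in this assay. Compound 4 is therefore estimated at 12000 nM, ranging from 5000 nM to 30000 nM, an expected step of a 1.1-fold higher number from compound 2 to compound 4 (0.06 log units; within the scatter).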

Compound 4, half-maximal inhibitory concentration: 15300 nM
Compound 4: middle estimate off by 1.3-fold (0.11 log units), on the low side, and the stated range covers the measured number.
By their numbers in this assay, from the lowest: compounds 2, 4, 3 and 1 (each within the scatter of the next).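

Within this assay, the exchange of the carbon rings on the aromatic nitrogen gives a 1.5-fold higher number from compound 2 to compound 4 (0.16 log units; within the scatter), and replacing 3-(trifluoromethyl)benzyl with cyclobutyl gives a 1.3-fold lower number from compound 1 to compound 4 (0.11 log units; within the scatter). This position has therefore carried cyclopentyl, cyclobutyl and 3-(trifluoromethyl)benzyl with no step beyond the scatter, so neither the size of the carbon ring nor the change from that benzyl group to cyclobutyl separates these compounds. Nothing available offers an explanation for these small steps. From the compounds shown here alone, whether an amine, a carboxylic acid or a longer alkyl chain at this nitrogen would move the number beyond the scatter remains open.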